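Compound 3: A Chlorophenyl Swap on an Inactive Compound

This account rests on a few compounds, and the source may have more. Where it says the series, first, only, none or still open, it means among the compounds named here.

In a functional assay on HCT-15 cells (Homo sapiens) for cytotoxicity, in the presence of a further agent that is not named here (on this read-out higher numbers stand for weaker inhibition and lower numbers for stronger inhibition), compound 2 (`Clc1ccc(-c2cc(-c3cccnc3)nc(-c3ccsc3)c2)o1`) stands at > 50000 nM, which is a limit of the assay and not a number. Its closest measured relative, compound 1 (`Clc1ccc(-c2cc(-c3cccnc3)nc(-c3cccs3)c2)o1`), gives 1240 nM. Among the compounds with values here, the only measured step is an at least 40-fold higher number from compound 1 to compound 2 (1.60 log units; beyond the scatter), with thiophen-3-yl in place of thiophen-2-yl on an aromatic carbon.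

Compound 3 (`Clc1cccc(-c2cc(-c3ccc(Cl)o3)cc(-c3ccsc3)n2)c1`) keeps the thiophen-3-yl group of compound 2 and changes another group: 3-chlorophenyl in place of pyridin-3-yl on an aromatic carbon. This puts 3-chlorophenyl in place of pyridin-3-yl, next to the ring nitrogen. Within the data shown here, no measured step covers this exchange, so the evidence bears on it only indirectly. The step of an at least 40-fold higher number from compound 1 to compound 2 (1.60 log units; beyond the scatter) shows that a single exchange on this core can move the number in this assay by a large amount. A number lower than the limit is therefore expected, though a second limit remains quite possible. The expected change is an at least 3.3-fold lower number from compound 2 to compound 3 (0.52 log units; beyond the scatter), a moderate step towards stronger inhibition. For compound 3 the estimate is 15000 nM, with an expected range from 3000 nM to 50000 nM.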

Compound 3, half-maximal inhibitory concentration: 13700 nM
For compound 3 the middle estimate is 1.1-fold (0.04 log units) above the measured one, and the stated range covers the measured number.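

In this assay, 3-chlorophenyl in place of pyridin-3-yl next to the ring nitrogen gives an at least 3.6-fold lower number from compound 2 to compound 3 (0.56 log units; beyond the scatter), so this position, and not only the point where the thiophene is attached, can move the number on the shared core. The group that enters has 0 hydrogen-bond acceptors where the group that leaves has 1, and compound 3 still gives a measurable number, so with thiophen-3-yl in place, that acceptor is not required for a reading below the limit. The step can be stated only as a bound because compound 2 sits at a limit of the assay and not at a number: the limit of > 50000 nM in this assay, at which 1 of the 3 values shown sits.

The compounds shown do not tell whether the same exchange would also lower the number with thiophen-2-yl in place, as in compound 1. Nor do they separate the part played by the chlorine from that of the lost ring nitrogen, as they include no unsubstituted phenyl and no phenyl carrying an amine or a carboxylic acid at this position.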